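Adding chloro to compound 1: working notes

The source may hold more compounds than are shown below. What is called first, only, known or untested is meant among the compounds shown, and "the series" means these compounds.

Measured in an ADME assay on Vero cells (Chlorocebus sabaeus) for cytotoxicity, read by CellTiter-Glo, with a stated time of 72 h; a higher number here means that more compound is tolerated, a lower number that less compound is tolerated:
Compound 1 `[O-][n+]1nc(NC2CC2)[n+]([O-])c2ccccc21`: 21 ug/mL
Compound 2 `[O-][n+]1nc(NC2CCCCC2)[n+]([O-])c2ccccc21`: 8.9 ug/mL

Compound 1 holds the higher of the two numbers, and the gap is a 2.4-fold lower number from compound 1 to compound 2 (0.37 log units; beyond the scatter). Compound 3 `[O-][n+]1nc(NC2CC2)[n+]([O-])c2ccc(Cl)cc21` keeps the cyclopropyl group of compound 1 and differs from it by chloro in place of hydrogen on an aromatic carbon. Among the compounds with values here, the only measured step, a 2.4-fold lower number from compound 1 to compound 2 (0.37 log units; beyond the scatter), is modest and concerns the group on the nitrogen. Within the data shown here, no measured step tests a change on the aromatic carbon, so this step is only a loose guide to size. A small move to a lower number in this assay is expected, and it may not clear the scatter. The estimate amounts to a 1.6-fold lower number from compound 1 to compound 3 (0.21 log units; within the scatter). Compound 3 is expected at 13 ug/mL, with an estimated range of 6 ug/mL to 26 ug/mL.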

Compound 3, half-maximal cytotoxic concentration: 1.3 ug/mL
The estimate for compound 3 lay 10-fold (1.00 log units) above the measured number; the whole stated range lies above it.
By their numbers in this assay, from the lowest: compound 3; then compound 2; then compound 1.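

In this assay, this aromatic carbon proves far more sensitive than the group on the nitrogen: chloro in place of hydrogen gives a 16-fold lower number from compound 1 to compound 3 (1.21 log units; beyond the scatter), against a 2.4-fold lower number from compound 1 to compound 2 (0.37 log units; beyond the scatter) for cyclohexyl in place of cyclopropyl. The entering group is a single chlorine atom, with no ring, no net charge and no hydrogen-bond donors or acceptors, so even a one-atom change on the aromatic carbon can set the number in this series. No supporting data bear on why this step is so large.

The compounds shown leave open whether the lower number belongs to chloro itself or would also come with fluoro or a methoxy group on the same aromatic carbon. They also leave open whether chloro on another aromatic carbon of the shared core would give a step of this size.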